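From 2-methoxyphenyl to cyclobutyl in the series

A few compounds are considered here, and "the series" means these few. Any claim that something is new, unique, unknown or untested is made for them only; others in the source may bear on it.

In an ADME assay on L6 cells (Rattus norvegicus) for cytotoxicity, read by fluorescence and resazurin assay, with a stated time of 72 h (on this read-out higher numbers stand for an effect only at larger amounts of compound and lower numbers for an effect already at smaller amounts), compound 3 (`COc1ccccc1-c1nc(=O)[nH]c2ccc(-c3cc[nH]n3)cc12`) stands at > 50000 nM as a limit and not a number. Compound 2 (`Cc1ccccc1-c1nc(=O)[nH]c2ccc(-c3cc[nH]n3)cc12`) gives > 50000 nM as a limit too. Compound 1 (`O=c1nc(-c2ccccc2)c2cc(-c3ccc(N4CCCC4)nc3)ccc2[nH]1`) gives > 50000 nM as a limit too. Compound 4 (`O=c1nc(C2CCC2)c2cc(-c3cc[nH]n3)ccc2[nH]1`) carries cyclobutyl in place of 2-methoxyphenyl on an aromatic carbon next to the ring nitrogen (cyclobutyl in place of 2-methoxyphenyl on an aromatic carbon). Among the measured compounds shown here, the one measured step (a step that the two limits leave unreadable from compound 2 to compound 3) has no readable size, and the only evidence is the shared limit (the limit of > 50000 nM in this assay, at which 3 of the 3 values shown sit). From compound 3 at > 50000 nM as a limit, no step beyond the scatter is expected in this assay and no direction can be given. The expected step (a number no higher from compound 3 to compound 4 (the limit leaves the size open)) stays within the scatter. Compound 4 is expected at 50000 nM (estimated range 25000 nM to 100000 nM).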

Compound 4, half-maximal effective concentration: > 50000 nM
Compound 4 gave a limit, no number; the forecaster's own chance of this, stated with the estimate: 80%; the middle value lies on the limit itself.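

No step can be read from compound 2 or compound 3 to compound 4 in this assay, because all the values are limits, not numbers: the limit of > 50000 nM in this assay, at which 4 of the 4 values shown sit.

The compounds shown leave open how far apart compound 2, compound 3 and compound 4 actually lie.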